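Amide variation on the shared core: toward compound 4

The compounds below may be only part of what the source reports. "The series", "measured", "known", "first", "only" and "open" are said of these compounds alone.

Measured so far:
compound 1 `CC(=O)Nc1ccc2nc(SCC(=O)NCc3ccccc3)sc2c1`: 9200 nM
compound 2 `COc1ccc(CNC(=O)CSc2nc3ccc(NC(=O)c4ccc([N+](=O)[O-])cc4)cc3s2)cc1`: > 100000 nM (a limit)
compound 3 `O=C(CSc1nc2ccc(NC(=O)CCl)cc2s1)NCc1ccccc1`: 1100 nM

In a functional assay on HepG2 cells (Homo sapiens) for cytotoxicity, read by MTT assay, with a stated time of 48 h (a lower number here means a stronger inhibitor, a higher number a weaker inhibitor), compound 1 gives 9200 nM, the highest of the two numbers shown. The nearest is compound 3, reached by an 8.4-fold lower number from compound 1 to compound 3 (0.92 log units; beyond the scatter), a chloro in place of hydrogen on a saturated chain carbon bound to a carbonyl carbon. For compound 2 the assay reports only a limit, > 100000 nM, not a number.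

Compound 4 `O=C(CSc1nc2ccc(NC(=O)c3ccc(Cl)cc3)cc2s1)NCc1ccccc1` is not yet measured. It differs from compound 1 by 4-chlorophenyl in place of methyl on a carbonyl carbon. For the measured compounds named here, no measured step alters exactly this place. The step to compound 3 touches the acetyl as well, but by a chloro rather than by an aromatic ring, so it bears only loosely on the change. Compound 2 also carries a carbonyl-bound aromatic ring on that nitrogen, and its result is the limit of > 100000 nM in this assay, at which 1 of the 3 values shown sits; it differs from compound 1 in a second place too, so it is at most a hint.

Relative to compound 1 a somewhat higher number is expected for compound 4, a 1.6-fold higher number from compound 1 to compound 4 (0.21 log units; within the scatter), with wide uncertainty. The estimate for compound 4 is 15000 nM, within 4000 nM to 60000 nM.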

Compound 4, half-maximal inhibitory concentration: 25400 nM
The estimate for compound 4 lay 1.7-fold (0.23 log units) below the measured number; the range from low to high includes it.
By their numbers in this assay, from the lowest: compound 3; then compound 1; then compound 4. At a limit, above all of these: compound 2.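

In this assay, 4-chlorophenyl in place of methyl on this carbonyl carbon gives a 2.8-fold higher number from compound 1 to compound 4 (0.44 log units; beyond the scatter), so this aromatic ring moves the number up, whereas the chloro of compound 3 moved it down at the same acetyl. Set against chloromethyl, the same ring gives a 23-fold higher number from compound 3 to compound 4 (1.36 log units; beyond the scatter), a far larger step, and the order on this carbonyl carbon runs chloromethyl, methyl, 4-chlorophenyl, from lowest number to highest. Compound 2, which also carries an aromatic ring on such a carbonyl but differs in a second place, gives a limit and not a number: the limit of > 100000 nM in this assay, at which 1 of the 4 values shown sits.

As far as these compounds go, whether the rise belongs to the ring or to its chloro stays open, and a plain phenyl on this carbonyl carbon would separate the two. Also open, from the compounds shown here alone, is whether the low number of compound 3 is specific to chloromethyl, which a hydroxymethyl or a bromomethyl group would test.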